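The compounds below may be only part of what the source reports. "The series", "measured", "known", "first", "only" and "open" are said of these compounds alone.

In a physicochemical assay for solubility, read by HPLC, using the shake flask method, measured as kinetic solubility, with a stated time of 2 h, at pH 7.4 (a lower number here means a less soluble compound, a higher number a more soluble compound), three compounds of the shared core have been examined so far. Compound 1 `Cc1ccc(-c2cnn3c(NCc4ccccn4)cc(C)nc23)cc1` gives < 5000 nM, a limit of the assay rather than a number. Compound 2 `Cc1cc(NCc2ccccn2)n2ncc(Br)c2n1` gives 89300 nM. Compound 3 `Cc1cc(NCc2ccccn2)n2ncc(-c3ccc(F)c(Cl)c3)c2n1` gives < 5000 nM, again only a limit. Compound 3 therefore stands at the lower edge of what this assay reports, together with compound 1, as the limit of < 5000 nM in this assay, at which 2 of the 3 values shown sit, records.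

Compound 4 `Cc1cc(NCc2ccccn2)n2ncc(-c3ccsc3)c2n1` differs from compound 3 in one place: thiophen-3-yl in place of 3-chloro-4-fluorophenyl on an aromatic carbon. Going by the values given here, of the measured steps, the one from compound 1 to compound 2 is an at least 17-fold higher number from compound 1 to compound 2 (1.25 log units; beyond the scatter), the one from compound 2 to compound 3 is an at least 17-fold lower number from compound 2 to compound 3 (1.25 log units; beyond the scatter), and the one from compound 1 to compound 3 is a step that the two limits leave unreadable from compound 1 to compound 3. Both aryl groups examined so far sit at the limit, while only bromo lifts the number clearly. A thiophen-3-yl group, a smaller aromatic ring than either aryl group, is expected to leave compound 4 near that same limit or a little above it, so the step from compound 3 to compound 4 is estimated as an at least 1.2-fold higher number from compound 3 to compound 4 (0.07 log units; that floor lies within the scatter). Compound 4 is thus expected to give about 6000 nM, within a range from 2000 nM to 25000 nM.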

Compound 4, solubility: 9000 nM
Beside the measured number, compound 4's estimate is 1.5-fold (0.18 log units) below it, and the stated range covers the measured number.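

In this assay, going by these compounds alone, compound 4 is the first compound with an aromatic ring at this position, on an aromatic carbon of the five-membered aromatic ring with 2 nitrogen, to return a number rather than a limit. Even so, thiophen-3-yl does not match bromo here, with a 9.9-fold lower number from compound 2 to compound 4 (1.00 log units; beyond the scatter), so a ring at this position has now been read directly against the bromo compound. Against the two phenyl groups the picture is less firm, with an at least 1.8-fold higher number from compound 3 to compound 4 (0.25 log units; that floor lies within the scatter) and an at least 1.8-fold higher number from compound 1 to compound 4 (0.25 log units; that floor lies within the scatter), and neither floor separates compound 4 from those compounds, whose readings rest on one edge of the assay: the limit of < 5000 nM in this assay, at which 2 of the 4 values shown sit.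

The step between compound 1 and compound 3 cannot be read, so the two substituted phenyl groups cannot be ordered against each other, and the compounds shown do not separate the role of the five-membered ring from that of its sulfur. As far as these compounds go, it also remains open how a furan-3-yl ring, an unsubstituted phenyl ring or a small amine at this position would read in this assay.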